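The compounds below may be only part of what the source reports. "The series", "measured", "known", "first", "only" and "open" are said of these compounds alone.

Values measured so far in a physicochemical assay for lipophilicity, at pH 7.4; on this read-out lower numbers stand for lower lipophilicity and higher numbers for higher lipophilicity:

- compound 1 `CCCCCC/C=C\Cc1c(C)[nH]c2ccccc2c1=O` gives 5.94
- compound 2 `Cc1[nH]c2ccccc2c(=O)c1/C=C/c1ccccc1` gives 4.4
- compound 3 `COc1ccc2[nH]c(C)c(Br)c(=O)c2c1` gives 1.62

Compound 3, at 1.62, is the lowest of the three. Compound 2 is the nearest to it and compound 1 the furthest, and both gaps lie beyond the usual scatter. For the measured compounds named here, these three compounds differ in more than one place, so no measured pair isolates a single change, and none of them shows what the next change does.

The next compound to be measured is compound 4 `Cc1[nH]c2ccc(Br)cc2c(=O)c1Br`. It is reached from compound 3 by one change, bromo in place of methoxy on an aromatic carbon. The rest of the structure stays the same, and neither group carries a net charge.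

Going by the values given here, with no matched pair to calibrate against, the expectation in this assay is a moderate upward step, beyond the scatter, though its size is poorly defined. Compound 2 gives 4.4, and the value of compound 4 is expected to stay well under that number. The estimated change is a number 0.88 log units higher from compound 3 to compound 4 (beyond the scatter). For compound 4 the expected value is 2.5, with an estimated range of 1.9 to 3.2.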

Compound 4, distribution coefficient: 1.76
The estimate for compound 4 lay 0.74 log units above the measured number, and the stated range ends above it.
By their numbers in this assay, from the lowest: compounds 3 and 4 (each within the scatter of the next); then compound 2; then compound 1.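

In this assay, bromo in place of methoxy on this aromatic carbon gives a number 0.14 log units higher from compound 3 to compound 4 (within the scatter), so the two compounds cannot be told apart on this read-out. For the compounds shown here, this is the first comparison that isolates a single place, and it shows that this exchange, on a carbon meta to a fused ring and para to a fused ring, leaves no readable step, even though the hydrogen-bond acceptor counted on methoxy is absent from bromo. No measurement at hand accounts for the absence of a step.

One pair at one place cannot show whether this position is insensitive to substitution in general or whether methoxy and bromo simply happen to give matching numbers here. An amine, a carboxylic acid or a longer chain such as hexyl on the same aromatic carbon would test that, and the same exchange at another place on the shared core would show whether the result holds beyond this one position.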